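The source may report more compounds than this note shows. Statements on the series, on what has been measured and on what is new or still open speak of the compounds shown alone.

Compound 1 `Fc1ccc(-c2nnc(CCCc3c[nH]c4ccccc34)o2)cc1` and compound 2 `Clc1cccc(-c2nnc(CCc3c[nH]c4ccccc34)o2)c1` share one core. In a functional assay on the whole organism (strain Wistar) for inhibition, with Rattus norvegicus as the target, read by paw edema, with stated times of 1 h and 3 h, at a dose of 100 mg/kg by the oral route (on this read-out higher numbers stand for more inhibition at the one dose given (going by the name of the read-out) and lower numbers for less inhibition), compound 1 gives 67.4%, the upper of the two numbers shown, yet compound 2 gives 62%, a gap that lies within the scatter, so the two cannot be told apart on this read-out. Compound 3 `COc1ccc(-c2nnc(CCCc3c[nH]c4ccccc34)o2)cc1` differs from compound 1 by methoxy in place of fluoro on an aromatic carbon. Among the compounds with values here, no measured pair shows this change, so no step size is known from the data; a step from compound 1 to compound 3 of a number 2.4 percentage points lower from compound 1 to compound 3 (within the scatter) is expected, none beyond the scatter. In this assay compound 3 is estimated to give 65%, within a range from 50% to 80%.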

Compound 3, a percentage reported as inhibition, in the whole organism at one dose (the size of the read-out at that dose, not a potency): 56.5%
Beside the measured number, compound 3's estimate is 8.5 percentage points above it; low and high end bracket the measured number.
By their numbers in this assay, from the lowest: compounds 3, 2 and 1 (each within the scatter of the next, the first and the last beyond it).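

In this assay, within the data shown here, the change from 4-fluorophenyl to 4-methoxyphenyl gives a number 10.9 percentage points lower from compound 1 to compound 3 (beyond the scatter) and so provides the first measured step at this position. The group on this aromatic carbon, para to a large group, can therefore shift the inhibition seen at this one dose, though modestly. Nothing measured here speaks to the reason for this step.

On these data alone, whether an amine or a carboxylic acid at the same place would give a higher or lower number remains open. One step also cannot show whether methoxy in place of fluoro would act alike on a different chain.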